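Swapping methoxy for fluoro on the sulfonyl aryl group

A few compounds are considered here, and "the series" means these few. Any claim that something is new, unique, unknown or untested is made for them only; others in the source may bear on it.

Measured compounds:
Compound 1 `O=S(=O)(c1ccc(F)c(Cl)c1)c1cnc2cc(F)ccc2c1-c1cccc(F)c1` gives 0.25 mL/min in an ADME assay on microsomes from liver (Homo sapiens) for metabolic stability, tested at 2.5 uM; on this read-out higher numbers stand for fast clearance and lower numbers for slow clearance.
Compound 2 `O=S(=O)(c1cccc(F)c1)c1cnc2cc(F)ccc2c1-c1ccc(F)cc1` gives 0.11 mL/min in this assay.
Compound 3 `COc1ccc(S(=O)(=O)c2cnc3cc(F)ccc3c2-c2ccc(F)cc2)cc1Cl` gives 1.29 mL/min in this assay.

Compound 3 stands highest of the three numbers in this assay; compound 1 is nearest to it, and compound 2 is furthest. The step from compound 2 to compound 3 was a 12-fold higher number from compound 2 to compound 3 (1.07 log units; beyond the scatter), and it put both a chloro group and a methoxy group onto the ring on the sulfonyl sulfur at once.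

Compound 4 `O=S(=O)(c1ccc(F)c(Cl)c1)c1cnc2cc(F)ccc2c1-c1ccc(F)cc1` differs from compound 3 by fluoro in place of methoxy on an aromatic carbon. This removes the methoxy part of that earlier change while keeping the chloro group. Compound 1 carries the same 3-chloro-4-fluorophenyl on its sulfonyl sulfur, with a different fluorophenyl on the core, and its value of 0.25 mL/min sits well below that of compound 3. For compound 4 a step of a 5.2-fold lower number from compound 3 to compound 4 (0.71 log units; beyond the scatter) is therefore expected, downward and beyond the scatter. Compound 4 is estimated at 0.25 mL/min, with a range from 0.12 mL/min to 0.5 mL/min.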

Compound 4, intrinsic clearance in a liver preparation (reported as CLH), per the amount of preparation that the assay uses: 0.69 mL/min
Beside the measured number, compound 4's estimate is 2.8-fold (0.44 log units) below it; measured number outside the range, above it.
By their numbers in this assay, from the lowest: compound 2; then compound 1; then compounds 4 and 3 (each within the scatter of the next).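

In this assay, fluoro in place of methoxy gives a 1.9-fold lower number from compound 3 to compound 4 (0.27 log units; within the scatter), so this position does not separate the two groups here. The chloro-bearing ring does not need its methoxy group to stay well above compound 2: 3-chloro-4-fluorophenyl in place of 3-fluorophenyl on the sulfonyl sulfur gives a 6.3-fold higher number from compound 2 to compound 4 (0.80 log units; beyond the scatter). The fluorophenyl on the core also matters, since 4-fluorophenyl in place of 3-fluorophenyl gives a 2.8-fold higher number from compound 1 to compound 4 (0.44 log units; beyond the scatter), and a value for one sulfonyl aryl group therefore cannot simply be carried over to a compound with the other fluorophenyl.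

Why these numbers move stays unexplained, as nothing measured here bears on the cause. From the compounds shown here alone, it also remains open whether an amine or a carboxylic acid in place of the fluoro or methoxy group would read the same.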